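This account rests on a few compounds, and the source may have more. Where it says the series, first, only, none or still open, it means among the compounds named here.

In a functional assay on U-373MG ATCC cells (Homo sapiens) for inhibition, read by colorimetric assay and MTT assay, with a stated time of 72 h (on this read-out lower numbers stand for stronger inhibition and higher numbers for weaker inhibition), compound 1 `Cc1ccc2c(c1)-c1cnc(n1C)OCCCCCCCCO2` gives 57000 nM and compound 2 `COc1ccc2c(c1)-c1cnc(n1C)OCCCCCCCCO2` gives 63000 nM, so the two cannot be told apart. Compound 3 `Cn1c2cnc1OCCCCCCCCOc1ccc(F)cc1-2` differs from compound 2 in one place: fluoro in place of methoxy on an aromatic carbon. Among the measured compounds shown here, the only measured step at this aromatic carbon is a 1.1-fold higher number from compound 1 to compound 2 (0.04 log units; within the scatter), methoxy in place of methyl, and it lies within the scatter. One step is thin evidence, but it gives no reason to expect a change beyond the scatter in this assay. The expected step is a 1.1-fold lower number from compound 2 to compound 3 (0.02 log units; within the scatter). Compound 3 is estimated at 60000 nM, with an expected range of 30000 nM to 100000 nM.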

Compound 3, half-maximal inhibitory concentration: 73000 nM
Compound 3: the middle estimate sits 1.2-fold (0.09 log units) below what was measured; the range from low to high includes it.
By their numbers in this assay, from the lowest: compounds 1, 2 and 3 (each within the scatter of the next).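

Fluoro in place of methoxy (a 1.2-fold higher number from compound 2 to compound 3 (0.06 log units; within the scatter)) and fluoro in place of methyl (a 1.3-fold higher number from compound 1 to compound 3 (0.11 log units; within the scatter)) both stay within the scatter in this assay as well. Three groups have now stood on this aromatic carbon with no step beyond the scatter, and fluoro, with its single heavy atom, fits that reading too. Nothing measured here bears on why these groups read alike. On these data alone, whether an amine, a carboxylic acid or a longer chain on this carbon would give a step beyond the scatter stays open.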